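Compound 4 and the piperidin-4-yl carbonyl on the shared core

The source may report more compounds than this note shows. Statements on the series, on what has been measured and on what is new or still open speak of the compounds shown alone.

The series is built on a shared core, seen in compound 1 `O=C(c1ccccn1)N1CCC(NS(=O)(=O)c2cc(S(=O)(=O)c3ccccc3)ccc2C(F)(F)F)CC1`, with variation only at the group on a carbonyl carbon. In an assay on U2OS cells for inhibition of secreted frizzled-related protein 1 (Homo sapiens), read by a luciferase reporter, with a stated time of 18 h (on this read-out lower numbers stand for an effect already at smaller amounts and higher numbers for an effect only at larger amounts of compound), compound 1 gives 230 nM, the second highest of the three measured numbers. Compound 2 `O=C(O)CCCC(=O)N1CCC(NS(=O)(=O)c2cc(S(=O)(=O)c3ccccc3)ccc2C(F)(F)F)CC1` gives 570 nM in this assay, and compound 3 `CC(C)(C)OC(=O)N1CC[C@H](C(=O)N2CCC(NS(=O)(=O)c3cc(S(=O)(=O)c4ccccc4)ccc3C(F)(F)F)CC2)C1` gives 150 nM.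

The two steps already made at this position go in opposite directions: a 2.5-fold higher number from compound 1 to compound 2 (0.39 log units; beyond the scatter), whereas a 1.5-fold lower number from compound 1 to compound 3 (0.19 log units; within the scatter). Compound 4 `O=C(C1CCNCC1)N1CCC(NS(=O)(=O)c2cc(S(=O)(=O)c3ccccc3)ccc2C(F)(F)F)CC1` is the change (piperidin-4-yl in place of pyridin-2-yl on a carbonyl carbon). Within the data shown here, neither measured step involves this group, so the bearing of the earlier steps is only that changes at this carbonyl carbon moved the number modestly and not consistently in one direction. Compound 4 is therefore expected to lie close to compound 1, with a step of a 1.3-fold higher number from compound 1 to compound 4 (0.12 log units; within the scatter) in this assay, possibly slightly higher. The estimate for compound 4 in this assay is 300 nM, with a range from 120 nM to 800 nM.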

Compound 4, half-maximal effective concentration: 150 nM
Compound 4: middle estimate off by 2.0-fold (0.30 log units), on the high side, within the range that was stated.
By their numbers in this assay, from the lowest: compounds 3, 4 and 1 (each within the scatter of the next); then compound 2.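

In this assay the non-aromatic piperidin-4-yl ring, with its hydrogen-bond donor, can stand in for the aromatic pyridin-2-yl ring on this carbonyl carbon without leaving the scatter (a 1.5-fold lower number from compound 1 to compound 4 (0.19 log units; within the scatter)). It also cannot be told apart from the 1-(tert-butoxycarbonyl)pyrrolidin-3-yl group (no change at the digits printed from compound 3 to compound 4 (within the scatter)), while the remaining step is beyond the scatter (a 3.8-fold lower number from compound 2 to compound 4 (0.58 log units; beyond the scatter)), so among these four compounds only the 3-carboxypropyl group stands apart. Nothing measured here accounts for these results.

The compounds shown leave open whether the hydrogen-bond donor of piperidin-4-yl matters at all, which a 1-methylpiperidin-4-yl or a cyclohexyl group on the same carbonyl carbon could address. From the compounds shown here alone, it is also open whether an amide in place of the carboxylic acid of the 3-carboxypropyl chain would keep that group apart from the others.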